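A few compounds are considered here, and "the series" means these few. Any claim that something is new, unique, unknown or untested is made for them only; others in the source may bear on it.

Measured in a functional assay on brain (Rattus norvegicus, strain Wistar) for inhibition; on this read-out lower numbers stand for stronger inhibition and higher numbers for weaker inhibition:
- compound 1 `CCCCc1ccc(-c2c(C)[nH]c(=O)n2CCCC)cc1`: 12000 nM
- compound 2 `Cc1ccc(-c2c(C)[nH]c(=O)n2C)cc1`: 85300 nM
- compound 3 `Cc1[nH]c(=O)n(C)c1-c1ccc(C(C)(C)C)cc1`: 8400 nM

Compound 3 at 8400 nM and compound 1 at 12000 nM lie within the scatter of each other, while compound 2 stands well apart from both.

Next in the series is compound 4 `CCCCCCCc1ccc(-c2c(C)[nH]c(=O)n2C)cc1`, with heptyl in place of tert-butyl on an aromatic carbon of a six-membered aromatic ring of carbon only: heptyl in place of tert-butyl on an aromatic carbon.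

Among the compounds with values here, one measured step bears directly on this place, with tert-butyl in place of methyl on the same aromatic carbon: a 10-fold lower number from compound 2 to compound 3 (1.01 log units; beyond the scatter). That step is large and shows that this assay responds to the group at this place. It does not show how a straight chain compares with tert-butyl there. Within the data shown here, compound 1 does carry a straight chain at this place, but it also differs from compound 3 elsewhere, so it offers no clean step. Compound 1 at 12000 nM still gives some reason to expect compound 4 to remain in the same region.

No step beyond the scatter is therefore expected, and the expected step is a 1.7-fold lower number from compound 3 to compound 4 (0.23 log units; within the scatter). For compound 4 the estimate is 5000 nM, with an expected range from 1500 nM to 20000 nM.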

Compound 4, half-maximal inhibitory concentration: 8400 nM
For compound 4 the middle estimate is 1.7-fold (0.23 log units) below the measured one; low and high end bracket the measured number.
By their numbers in this assay, from the lowest: compounds 3, 4 and 1 (each within the scatter of the next); then compound 2.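

In this assay, no change at the digits printed from compound 3 to compound 4 (within the scatter) when heptyl replaces tert-butyl on this aromatic carbon, so the group can grow from 4 heavy atoms to 7 heavy atoms and change from branched to straight with no difference beyond the scatter. The straight chain also reaches the level of the branched group, with a 10-fold lower number from compound 2 to compound 4 (1.01 log units; beyond the scatter) for hexyl in place of hydrogen on the saturated chain carbon, so branching is not required for the large step first seen with tert-butyl. No measurement at hand explains why tert-butyl and heptyl read alike here.

Still open, on these data alone, is how the number runs between methyl and heptyl on this carbon, for example with a straight propyl chain, and whether a longer chain such as decyl, or an amine or a carboxylic acid at the end of the chain, would hold this level or move away from it. Compound 1 differs from compound 4 in more than one place, so the contribution of its second butyl group cannot be separated from that of the chain on the aromatic carbon.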